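The source may report more compounds than this note shows. Statements on the series, on what has been measured and on what is new or still open speak of the compounds shown alone.

Compound 1, `COc1ccc(-c2cc(/C=C/C(=O)c3ccc(N)cc3)[nH]n2)cc1`, gives 60% in a functional assay on T47D cells (Homo sapiens) for cytotoxicity, read by sulforhodamine B assay, with a stated time of 48 h, tested at 1 uM; on this read-out higher numbers stand for a weaker effect at the one concentration tested and lower numbers for a stronger effect.
Compound 2, `COc1cc(-c2cc(/C=C/C(=O)c3ccc(N)cc3)[nH]n2)cc(OC)c1OC`, gives 66% in this assay.

Of the two compounds measured, compound 2 has the higher number in this assay, but its nearest neighbour, compound 1, lies only a little lower, and that gap falls within the usual scatter, so the two compounds cannot be told apart on this read-out. The account now turns to compound 3, `COc1cc(-c2cc(/C=C/C(=O)c3ccc(Cl)c(Cl)c3)[nH]n2)cc(OC)c1OC`, which has not been measured. Compound 3 differs from compound 2 in one place: 3,4-dichlorophenyl in place of 4-aminophenyl on a carbonyl carbon. Going by the values given here, no step between two measured compounds speaks to this change, so its effect on this assay is unknown; the two measured values only show that compounds of this shape give moderate numbers at the one concentration tested. Compound 3 is therefore expected to sit near compound 2, with the step of a number 6 percentage points lower from compound 2 to compound 3 (within the scatter) estimated as small and of no clear direction beyond the scatter. The estimate for compound 3 is 60%, within a range from 40% to 85%.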

Compound 3, a percentage reported as activity, at one concentration (the size of the read-out at that concentration, not a potency): 62%
Compound 3: middle estimate off by 2 percentage points, on the low side, within the range that was stated.
By their numbers in this assay, from the lowest: compounds 1, 3 and 2 (each within the scatter of the next).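

In this assay, going by these compounds alone, the replacement of 4-aminophenyl by 3,4-dichlorophenyl on the carbonyl carbon gives a number 4 percentage points lower from compound 2 to compound 3 (within the scatter), the first step that can be read at this position. The two aryl groups differ in their substituents and in the hydrogen-bond donor and acceptor counted on 4-aminophenyl but not on 3,4-dichlorophenyl, yet this read-out at the one concentration tested does not separate compound 2 from compound 3. No measurement shown bears on the reason for this result.

The compounds shown leave open whether a different group on this carbonyl carbon, such as a phenyl ring carrying a carboxylic acid, a morpholine ring or a longer alkyl chain, would give a value beyond the scatter from compound 2 in this assay. As far as these compounds go, it also remains open whether 3,4-dichlorophenyl would give a similar reading on the core of compound 1, and, with each compound read at a single concentration, how the three compare at any other concentration.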